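From Phenyl to Pyridine in a Furan-Bearing Series

The source may hold more compounds than are shown below. What is called first, only, known or untested is meant among the compounds shown, and "the series" means these compounds.

In a functional assay on HCT-116 cells (Homo sapiens) for inhibition, with a stated time of 72 h (a higher number here means a weaker inhibitor, a lower number a stronger inhibitor), compound 2 `NC1CCC(Nc2nc(NCc3ccc(-c4ccco4)cc3)c3ncn(C4CCCC4)c3n2)CC1` gives 129 nM, the lowest of the three numbers. Compound 1 `NC1CCC(Nc2nc(NCc3ccc(-c4cccc(F)c4)cc3)c3ncn(C4CCCC4)c3n2)CC1` gives 551 nM, and compound 3 `CC(C)(O)CNc1nc(NCc2ccc(-c3ccco3)cc2)c2ncn(C3CCCC3)c2n1` gives 16700 nM. Compound 4 `NC1CCC(Nc2nc(NCc3ccc(-c4ccco4)nc3)c3ncn(C4CCCC4)c3n2)CC1` carries 6-(furan-2-yl)pyridin-3-yl in place of 4-(furan-2-yl)phenyl on a saturated chain carbon bound to a nitrogen on an aromatic ring. Going by the values given here, the closest precedent is the modest 4.3-fold lower number from compound 1 to compound 2 (0.63 log units; beyond the scatter), which also altered this aryl portion. The large 130-fold higher number from compound 2 to compound 3 (2.11 log units; beyond the scatter) replaced 4-aminocyclohexyl, which compound 4 retains, so it bears little on this change. No step beyond the scatter is expected, only a slight rise: a 1.5-fold higher number from compound 2 to compound 4 (0.17 log units; within the scatter). For compound 4 the estimated value is 190 nM, with an expected range from 70 nM to 520 nM.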

Compound 4, half-maximal inhibitory concentration: 86 nM
For compound 4 the middle estimate is 2.2-fold (0.34 log units) above the measured one; low and high end bracket the measured number.
By their numbers in this assay, from the lowest: compounds 4 and 2 (each within the scatter of the next); then compound 1; then compound 3.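

In this assay the step to 6-(furan-2-yl)pyridin-3-yl gives a 1.5-fold lower number from compound 2 to compound 4 (0.18 log units; within the scatter) and so leaves the number within the scatter. The earlier step in this aryl portion exchanged only the 3-fluorophenyl and furan-2-yl groups, whereas this one shows that the six-membered ring itself accepts a ring nitrogen and a further hydrogen-bond acceptor without a measurable loss. Nothing measured here addresses why the two compounds read alike. Going by these compounds, whether the same tolerance holds with 3-fluorophenyl on the pyridine remains open, as does the outcome with a pyrimidine ring or a methoxy group.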